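Swapping the amide ring from pyrazole to furan

The compounds below may be only part of what the source reports. "The series", "measured", "known", "first", "only" and "open" are said of these compounds alone.

Measured compounds:
compound 1 `CCCCCCCCCCCC[C@@H](O)[C@H]1CC[C@H]([C@H](O)CCCCCCCCCCNC(=O)c2cncs2)O1`: 100000 nM
compound 2 `CCCCCCCCCCCC[C@@H](O)[C@H]1CC[C@H]([C@H](O)CCCCCCCCCCNC(=O)c2ccsc2)O1`: 2190 nM
compound 3 `CCCCCCCCCCCC[C@@H](O)[C@H]1CC[C@H]([C@H](O)CCCCCCCCCCNC(=O)c2ccnn2C)O1`: 100000 nM

Among the measured compounds shown here, in a functional assay on HCC 2998 cells (Homo sapiens) for inhibition, read by colorimetric assay and sulforhodamine B assay, with a stated time of 48 h (a higher number here means a weaker inhibitor of growth, a lower number a stronger inhibitor of growth), compound 3 gives 100000 nM, level with compound 1 and together with it the highest of the three numbers; its only change beyond the scatter is a 46-fold higher number from compound 2 to compound 3 (1.66 log units; beyond the scatter). Compound 4 `CCCCCCCCCCCC[C@@H](O)[C@H]1CC[C@H]([C@H](O)CCCCCCCCCCNC(=O)c2ccoc2)O1` carries furan-3-yl in place of 1-methyl-1H-pyrazol-5-yl on a carbonyl carbon. For the measured compounds named here, the steps that bear on this are a 46-fold lower number from compound 1 to compound 2 (1.66 log units; beyond the scatter) and a 46-fold higher number from compound 2 to compound 3 (1.66 log units; beyond the scatter), both large, and both point the same way: the ring with one hetero atom attached through its 3-position gave the far lower number. Since furan-3-yl resembles thiophen-3-yl more than it does the rings of compounds 1 and 3, a large fall is expected, a 20-fold lower number from compound 3 to compound 4 (1.30 log units; beyond the scatter). Compound 4 is estimated at 5000 nM, with a range from 1500 nM to 60000 nM.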

Compound 4, concentration for 50% growth inhibition: 79400 nM
For compound 4 the middle estimate is 16-fold (1.20 log units) below the measured one; the whole stated range lies below it.
By their numbers in this assay, from the lowest: compound 2; then compounds 4, 1 and 3 (each within the scatter of the next).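

A single hetero atom in a ring attached through its 3-position is therefore not enough for a low number in this assay, since furan-3-yl in place of thiophen-3-yl loses almost all of the gain (a 36-fold higher number from compound 2 to compound 4 (1.56 log units; beyond the scatter)). Furan-3-yl stays level with the other two rings (a 1.3-fold lower number from compound 3 to compound 4 (0.10 log units; within the scatter); a 1.3-fold lower number from compound 1 to compound 4 (0.10 log units; within the scatter)), leaving thiophen-3-yl alone among these four. No measurement here explains this. As far as these compounds go, whether thiophen-3-yl owes its number to the ring sulfur or to the point of attachment remains open, and thiophen-2-yl or phenyl on the same carbonyl carbon would test this.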